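The source may report more compounds than this note shows. Statements on the series, on what has been measured and on what is new or still open speak of the compounds shown alone.

Measured so far in a functional assay on HCT-116 cells (Homo sapiens) for antiproliferative activity, read by MTT assay, with a stated time of 72 h; on this read-out lower numbers stand for stronger inhibition and higher numbers for weaker inhibition:

Compound 1 `O=C1COc2ccc(-c3cnc(Cl)c(NS(=O)(=O)c4ccc(F)cc4)c3)cc2N1c1ccc(F)cc1` gives 34200 nM
Compound 2 `COc1ncc(-c2ccc3c(c2)N(c2ccccc2)C(=O)CO3)cc1NS(=O)(=O)c1ccc(F)cc1` gives 18800 nM

Only these two numbers are available, and they lie within the usual scatter of each other. Compound 2 therefore cannot be told apart from compound 1 on this read-out, and both sit in the same high range of numbers, where inhibition is weak.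

Compound 3 `O=C1COc2ccc(-c3cnc(Cl)c(NS(=O)(=O)c4ccc(F)cc4)c3)cc2N1c1ccccc1` keeps the frame of compound 2 but has chloro in place of methoxy on an aromatic carbon, next to the ring nitrogen: chloro in place of methoxy on an aromatic carbon. Among the measured compounds shown here, no measured pair isolates this change, so there is no direct step to lean on. The closest guide is indirect. Compound 1 carries chloro on that carbon and gives 34200 nM, although it also differs from compound 2 elsewhere. In this assay no step beyond the scatter is therefore expected, at most a slight drift toward a higher number. The expected change is a 1.3-fold higher number from compound 2 to compound 3 (0.12 log units; within the scatter). For compound 3 the estimated value is 25000 nM, with an expected range from 10000 nM to 60000 nM.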

Compound 3, half-maximal inhibitory concentration: 39800 nM
Estimate against measurement, compound 3: 1.6-fold (0.20 log units) below; low and high end bracket the measured number.
By their numbers in this assay, from the lowest: compounds 2, 1 and 3 (each within the scatter of the next, the first and the last beyond it).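

In this assay, among the compounds shown here, chloro in place of methoxy on the aromatic carbon next to the ring nitrogen gives the first direct reading at this position (a 2.1-fold higher number from compound 2 to compound 3 (0.33 log units; beyond the scatter)), a modest step in which the methoxy compound shows the stronger inhibition. Hydrogen in place of fluoro on an aromatic carbon gives a different picture (a 1.2-fold higher number from compound 1 to compound 3 (0.07 log units; within the scatter)), because this step stays within the scatter and the assay does not separate those two compounds, so of the two single changes shown, only the one at the position next to the ring nitrogen registers. Nothing measured here bears on what lies behind the step between methoxy and chloro.

The compounds shown leave open whether the trend at this position extends to other groups, such as an amine, a hydroxyl or a nitrile, since the reading rests on a single pair only just beyond the scatter. They also leave open whether any change at this carbon can bring the numbers out of the high range, where all three compounds still sit and inhibition remains weak.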